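Chlorophenyl swap on the arylidene series

This account rests on a few compounds, and the source may have more. Where it says the series, first, only, none or still open, it means among the compounds named here.

The set holds three measured compounds on a shared core. In an assay on HL-60 cells for inhibition of glutathione S-transferase P (Homo sapiens), read by spectrophotometry, tested at 20 uM (a lower number here means less inhibition, a higher number more inhibition at the concentration tested (going by the name of the read-out)), compound 1 `Cc1ccc2c(c1)C(=O)/C(=C/c1ccccc1)CN2CC(=O)O` gives 4.23%, compound 2 `Cc1cc(C)cc(/C=C2\CN(CC(=O)O)c3c(C)cccc3C2=O)c1` gives 17.5%, and compound 3 `Cc1cccc(/C=C2\CN(CC(=O)O)c3c(Cl)cccc3C2=O)c1` gives 45.6%. Compound 2 thus stands second highest of the three: compound 1 lies below it beyond the scatter, compound 3 above it beyond the scatter. Compound 4 `Cc1cccc2c1N(CC(=O)O)C/C(=C\c1ccccc1Cl)C2=O` is not yet measured; it differs from compound 2 by 2-chlorophenyl in place of 3,5-dimethylphenyl on a double-bonded chain carbon bound to a double-bonded ring carbon. For the measured compounds named here, no measured pair isolates this change on its own, so the expectation rests on the spread of the three values alone. The step of a number 2.5 percentage points higher from compound 2 to compound 4 (within the scatter) is expected to stay within the scatter, with no clear direction. Compound 4 is therefore estimated at 20%, within 5% to 40% in this assay.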

Compound 4, a percentage reported as inhibition, at one concentration (the size of the read-out at that concentration, not a potency): 51.9%
Compound 4: middle estimate off by 31.9 percentage points, on the low side; the measured number lies above the stated range.
By their numbers in this assay, from the lowest: compound 1; then compound 2; then compounds 3 and 4 (each within the scatter of the next).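

For the compounds shown here, at the double-bonded chain carbon bound to a double-bonded ring carbon, 2-chlorophenyl in place of 3,5-dimethylphenyl in this assay gives a step of a number 34.4 percentage points higher from compound 2 to compound 4 (beyond the scatter) and is the only single-place comparison. The aryl group at this position can therefore, on its own, move inhibition well beyond the scatter. Nothing available explains the size of this step.

The swap changes both the chlorine and the two methyl groups, so the contribution of each remains unresolved. On these data alone, how a 2-aminophenyl or 2-methoxyphenyl group would read at this position also remains open.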